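This account rests on a few compounds, and the source may have more. Where it says the series, first, only, none or still open, it means among the compounds named here.

In a functional assay on K562 cells (Homo sapiens) for inhibition, read by trypan blue exclusion, with a stated time of 48 h (a higher number here means a weaker inhibitor, a lower number a stronger inhibitor), compound 1 (`Cc1ccc(NC(=O)/C=C/c2ccccc2)c(C(N)=O)c1`) gives 5500 nM as its half-maximal inhibitory concentration. For compound 2 (`NC(=O)c1cc(Br)ccc1NC(=O)/C=C/c1cccc(Cl)c1`) the result > 10000 nM is a limit of the assay and not a number. Compound 3 (`Cc1cccc(/C=C/C(=O)Nc2ccc(Br)cc2C(N)=O)c1`) is still unmeasured and differs from compound 2 in one place: methyl in place of chloro on an aromatic carbon (methyl in place of chloro on an aromatic carbon, meta to a large group). Within the data shown here, no measured pair shows this swap, so any forecast is rough. Among the measured compounds shown here, compound 1 at 5500 nM provides the only firm number here. A value not far from the limit of compound 2 seems a fair expectation for compound 3, though another limit result is quite possible. The estimate means an at least 1.2-fold lower number from compound 2 to compound 3 (0.09 log units; that floor lies within the scatter) as a modest expected step towards stronger inhibition. For compound 3 the estimated half-maximal inhibitory concentration is 8000 nM with 3500 nM to 15000 nM as the expected range.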

Compound 3, half-maximal inhibitory concentration: > 10000 nM
Compound 3 ended at the assay's limit; the forecaster's own chance of this, stated with the estimate: 40%; at least 1.2-fold (0.09 log units) between middle value and limit.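

Compound 2 and compound 3 both end at a limit of the assay and not at a number, so no step can be read between them: the limit of > 10000 nM in this assay, at which 2 of the 3 values shown sit.

The compounds shown leave open how strongly either compound inhibits, and whether methyl in place of chloro changes that at all.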